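This account rests on a few compounds, and the source may have more. Where it says the series, first, only, none or still open, it means among the compounds named here.

Compounds measured in an ADME assay on Caco-2 cells (Homo sapiens) for permeability, read by LC-MS, in the apical to basolateral direction, with a stated time of 90 min; on this read-out lower numbers stand for lower permeability and higher numbers for higher permeability:
compound 1 `COc1ncc(-c2cc(OC3CCCCC3)c3ncnc(C)c3c2)cc1NS(=O)(=O)c1ccc(F)cc1F` gives 16 10^-6 cm/s;
compound 2 `COc1ncc(-c2cc(O[C@@H]3CCOC3)c3ncnc(C)c3c2)cc1NS(=O)(=O)c1ccc(F)cc1F` gives 38 10^-6 cm/s;
compound 3 `COc1ncc(-c2cc(OC3CCOCC3)c3ncnc(C)c3c2)cc1NS(=O)(=O)c1ccc(F)cc1F` gives 42 10^-6 cm/s.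

Compound 1 holds the lowest of the three numbers. The unmeasured compound 4 `COc1ncc(-c2cc(OC3CCN(C)CC3)c3ncnc(C)c3c2)cc1NS(=O)(=O)c1ccc(F)cc1F` differs from compound 1 in one place: 1-methylpiperidin-4-yl in place of cyclohexyl on an oxygen on an aromatic ring. Two measured steps start from the same cyclohexyl and bear on this change: a 2.4-fold higher number from compound 1 to compound 2 (0.38 log units; beyond the scatter) and a 2.6-fold higher number from compound 1 to compound 3 (0.42 log units; beyond the scatter); between the two ethers themselves, a 1.1-fold higher number from compound 2 to compound 3 (0.04 log units; within the scatter). Both measured steps, however, bring in a ring containing oxygen, whereas compound 4 brings in a ring with a nitrogen bearing a methyl, so they guide only loosely. For compound 4 a change of a 1.3-fold lower number from compound 1 to compound 4 (0.12 log units; within the scatter) is expected, with the estimate of 12 10^-6 cm/s in this assay spanning 4 10^-6 cm/s to 35 10^-6 cm/s.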

Compound 4, apparent permeability: 4.5 10^-6 cm/s
The estimate for compound 4 lay 2.7-fold (0.43 log units) above the measured number; the measured number falls inside the stated range.
By their numbers in this assay, from the lowest: compound 4; then compound 1; then compounds 2 and 3 (each within the scatter of the next).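

In this assay the substituent on this oxygen on an aromatic ring moves the number downward as well as upward: 1-methylpiperidin-4-yl in place of cyclohexyl gives a 3.6-fold lower number from compound 1 to compound 4 (0.55 log units; beyond the scatter), opposite in direction to the steps from cyclohexyl to oxolan-3-yl and oxan-4-yl. A hetero atom in the ring therefore does not by itself set the direction, and the gap between the nitrogen and oxygen rings is wider still (a 9.3-fold lower number from compound 3 to compound 4 (0.97 log units; beyond the scatter); an 8.4-fold lower number from compound 2 to compound 4 (0.93 log units; beyond the scatter)). Nothing available explains this difference. The compounds shown leave open whether a piperidin-4-yl ring without the methyl on nitrogen would follow compound 4 or the oxygen rings. They also leave open how an open-chain amine, such as 2-(dimethylamino)ethyl, would behave on this oxygen.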